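From 2-fluorophenyl to 3-fluorophenyl: an expected flat step

The source may report more compounds than this note shows. Statements on the series, on what has been measured and on what is new or still open speak of the compounds shown alone.

In a functional assay on B16 cells (Mus musculus) for cytotoxicity, read by CCK-8 assay, with a stated time of 24 h (a lower number here means a stronger inhibitor, a higher number a weaker inhibitor), compound 1 (`COc1ccccc1Oc1c(N)nc(-c2ccccc2)nc1OCCO`) gives 31100 nM and compound 2 (`COc1ccccc1Oc1c(N)nc(-c2ccc(C)cc2)nc1OCCO`) gives 8430 nM, while compound 3 (`COc1ccccc1Oc1c(N)nc(-c2ccccc2F)nc1OCCO`) stands at 11800 nM on the same read-out. The numbers show a 1.4-fold higher number from compound 2 to compound 3 (0.15 log units; within the scatter) as a step within the scatter and a 2.6-fold lower number from compound 1 to compound 3 (0.42 log units; beyond the scatter) as one beyond it. Compound 3 therefore stands level with compound 2 and under compound 1. The change to compound 4 (`COc1ccccc1Oc1c(N)nc(-c2cccc(F)c2)nc1OCCO`) is 3-fluorophenyl in place of 2-fluorophenyl on an aromatic carbon and puts 3-fluorophenyl in place of 2-fluorophenyl on an aromatic carbon between two ring nitrogen atoms, with the same atoms joined differently. The modest steps nearest to it replace hydrogen: fluoro gave a 2.6-fold lower number from compound 1 to compound 3 (0.42 log units; beyond the scatter) and methyl gave a 3.7-fold lower number from compound 1 to compound 2 (0.57 log units; beyond the scatter) on an aromatic carbon. Among the compounds with values here, no measured step moves a fluoro group, so no step beyond the scatter is expected, and the expected change is a 1.1-fold lower number from compound 3 to compound 4 (0.03 log units; within the scatter) in either direction. Compound 4 is estimated at 11000 nM with a range from 5500 nM to 22000 nM in this assay for now.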

Compound 4, half-maximal inhibitory concentration: 20900 nM
Beside the measured number, compound 4's estimate is 1.9-fold (0.28 log units) below it; measured number inside the range.
By their numbers in this assay, from the lowest: compounds 2, 3, 4 and 1 (each within the scatter of the next, the first and the last beyond it).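

Moving the fluoro group, from 2-fluorophenyl to 3-fluorophenyl on the aromatic carbon between two ring nitrogen atoms, gives a 1.8-fold higher number from compound 3 to compound 4 (0.25 log units; within the scatter) in this assay, so this change does not separate the two isomers. Even so, fluoro in place of hydrogen now gives a 1.5-fold lower number from compound 1 to compound 4 (0.17 log units; within the scatter), whereas the 2-fluorophenyl step from compound 1 lay beyond the scatter, and 3-fluorophenyl in place of 4-methylphenyl gives a 2.5-fold higher number from compound 2 to compound 4 (0.39 log units; beyond the scatter), a gap that compound 3 did not open from compound 2. Nothing available explains why these steps differ.

Going by these compounds, it remains open how 4-fluorophenyl or 3-methylphenyl would read at this position, which would show whether the ring place or the group matters more. Also open, on these data alone, is whether a carboxylic acid or an amine on this phenyl ring would move the number further than fluoro or methyl does.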